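Cytotoxicity of compound 4, a dibromo-methylphenyl ether

The source may report more compounds than this note shows. Statements on the series, on what has been measured and on what is new or still open speak of the compounds shown alone.

Compound 3 `COc1cc(C#N)ccc1Oc1nc(Nc2ccc(C#N)cc2)nc2ccccc12` stands at a limit in an ADME assay on MT4 cells (Homo sapiens) for cytotoxicity, read by MTT assay, with a stated time of 4 days; on this read-out lower numbers stand for higher toxicity in this test and higher numbers for lower toxicity in this test: compound 3 gives >= 140000 nM, a limit of the assay rather than a number. Compound 1 `COc1ccc(Oc2nc(Nc3ccc(C#N)cc3)nc3ccccc23)cc1` gives 340000 nM in this assay. Compound 2 `Cc1cc(C)c(Oc2nc(Nc3ccc(C#N)cc3)nc3ccccc23)c(C)c1` gives > 34000 nM, which is also a limit. The change to compound 4 `Cc1cc(Br)cc(Br)c1Oc1nc(Nc2ccc(C#N)cc2)nc2ccccc12` is 2,4-dibromo-6-methylphenyl in place of 4-cyano-2-methoxyphenyl on an oxygen on an aromatic ring. The steps that touch this position are a step that the limit leaves unreadable from compound 1 to compound 3 and a step that the two limits leave unreadable from compound 2 to compound 3; their sizes stay hidden because the limits the limit of > 34000 nM in this assay, at which 1 of the 3 values shown sits, and the limit of >= 140000 nM in this assay, at which 1 of the 3 values shown sits, cap the values. These steps therefore give no direction, and no step beyond the scatter is expected in this assay; the change to compound 4 is expected to amount to an at least 1.4-fold lower number from compound 3 to compound 4 (0.14 log units; that floor lies within the scatter). Compound 4 is estimated to give 100000 nM, between 20000 nM and 340000 nM.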

Compound 4, half-maximal cytotoxic concentration: 150000 nM
For compound 4 the middle estimate is 1.5-fold (0.18 log units) below the measured one; the range from low to high includes it.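

In this assay, this position now gives its first readable step, a 2.3-fold lower number from compound 1 to compound 4 (0.36 log units; beyond the scatter), with 2,4-dibromo-6-methylphenyl in place of 4-methoxyphenyl. This shows that a group with no hydrogen-bond acceptors can still give an exact value here. The steps to compound 4 from compound 2 and from compound 3 cannot be read, since each starts at a limit: the limit of > 34000 nM in this assay, at which 1 of the 4 values shown sits, and the limit of >= 140000 nM in this assay, at which 1 of the 4 values shown sits.

This step covers the change of the whole group. The data do not split it between the bromines and the methyl. From the compounds shown here alone, how an amine or a carboxylic acid on this ring would read in this assay also stays open.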